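Fluoro in place of hydrogen on the phenyl of compound 2

The source may hold more compounds than are shown below. What is called first, only, known or untested is meant among the compounds shown, and "the series" means these compounds.

Compound 1, `COc1cc(-n2ncnc2-c2cccc([N+](=O)[O-])c2)cc(OC)c1OC`: > 10000 nM in a functional assay on MCF7 cells (Homo sapiens) for antiproliferative activity, read by MTT assay, with a stated time of 72 h; a higher number here means a weaker inhibitor, a lower number a stronger inhibitor
Compound 2, `COc1cc(-c2ncnn2-c2ccccc2)cc(OC)c1OC`: > 10000 nM
Compound 3, `CCOc1ccc(-c2ncnn2-c2cc(OC)c(OC)c(OC)c2)cc1Cl`: 17 nM

Of the three measured compounds, compound 3 gives a numerical value, 17 nM, in this assay. Compound 1 reaches only the limit of this assay, > 10000 nM, and not a number. Compound 2 likewise sits at the limit of this assay, > 10000 nM, so its position is known only as being no stronger than that. This is where compound 2 stands: at the limit of > 10000 nM in this assay, at which 2 of the 3 values shown sit, with no number of its own against which a neighbouring structure can be measured.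

Compound 4, `COc1cc(-c2ncnn2-c2cccc(F)c2)cc(OC)c1OC`, is not yet measured in this assay. It differs from compound 2 in one place: fluoro in place of hydrogen on an aromatic carbon.

Going by the values given here, no step between two measured compounds is available to anchor the size of this change. Because compound 2 sits at the limit of > 10000 nM in this assay, at which 2 of the 3 values shown sit, the step from compound 2 to compound 4 cannot be read against a number, and the expectation is that it stays within the scatter, with a fair chance that the assay again reports only a limit for compound 4. The estimated value for compound 4 is 9000 nM, in the range 1500 nM to 30000 nM, meaning an expected step of an at least 1.1-fold lower number from compound 2 to compound 4 (0.04 log units; that floor lies within the scatter).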

Compound 4, half-maximal inhibitory concentration: > 10000 nM
Compound 4: a limit, no number; the forecaster's own chance of this, stated with the estimate: 70%; at least 1.1-fold (0.04 log units) between middle value and limit.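

In this assay compound 4 gives > 10000 nM, a limit and not a number. Compound 2 also stands at a limit, so no step can be read between compound 2 and compound 4: the limit of > 10000 nM in this assay, at which 3 of the 4 values shown sit.

The compounds shown leave open the size and direction of any change from phenyl to 3-fluorophenyl.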